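Replacing the terminal amine of compound 2: an expectation

The source may hold more compounds than are shown below. What is called first, only, known or untested is meant among the compounds shown, and "the series" means these compounds.

Of the compounds shown here, two have been measured in an assay for binding affinity, read by spectrophotometry; on this read-out lower numbers stand for stronger inhibition and higher numbers for weaker inhibition. Compound 1 `C[C@H](CCCN1CCCC1)Nc1ccnc2cc(Cl)ccc12` gives 140000 nM, and compound 2 `C[C@@H](CCCN1CCCC1)Nc1ccnc2cc(Cl)ccc12` gives 180000 nM. The step of a 1.3-fold higher number from compound 1 to compound 2 (0.11 log units; within the scatter) reflects only (the fact that compounds 1 and 2 differ only in the configuration as drawn), and compound 2 stands alongside compound 1 with no separation beyond the scatter. Compound 3 `C[C@@H](CCCN1CCN(C)CC1)Nc1ccnc2cc(Cl)ccc12` differs from compound 2 by 4-methylpiperazin-1-yl in place of pyrrolidin-1-yl on a saturated chain carbon, four bonds along the chain from a nitrogen on an aromatic ring. Among the measured compounds shown here, the single measured step concerns configuration alone and does not touch this change, leaving no basis for expecting a shift beyond the scatter in this assay. Compound 3 is estimated at 180000 nM, between 50000 nM and 600000 nM. The expected step is no change at the digits printed from compound 2 to compound 3 (within the scatter).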

Compound 3, half-maximal inhibitory concentration: 140000 nM
For compound 3 the middle estimate is 1.3-fold (0.11 log units) above the measured one; the range from low to high includes it.
By their numbers in this assay, from the lowest: compounds 1, 3 and 2 (each within the scatter of the next).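

In this assay, among the compounds shown here, 4-methylpiperazin-1-yl in place of pyrrolidin-1-yl on the saturated chain carbon gives a 1.3-fold lower number from compound 2 to compound 3 (0.11 log units; within the scatter), the first reading on the terminal ring itself, since the earlier compounds spoke only to configuration. At this place the two rings do not separate in this assay, despite their different ring size and heavy-atom count. Nothing at hand bears on why they read alike.

Going by these compounds, whether a carboxylic acid or a primary amine at this place, or a longer chain carrying the ring, would move the number beyond the scatter remains open. Also open, on these data alone, is whether configuration would matter with 4-methylpiperazin-1-yl in place.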